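A few compounds are considered here, and "the series" means these few. Any claim that something is new, unique, unknown or untested is made for them only; others in the source may bear on it.

Compound 1 `O=C(N/N=C/c1ccc(Br)cc1)Nc1ccc(Oc2ccnc3[nH]ccc23)c(F)c1` is the starting point. In a functional assay on HepG2 cells (Homo sapiens) for antiproliferative activity, read by MTT assay, with a stated time of 72 h (on this read-out higher numbers stand for weaker inhibition and lower numbers for stronger inhibition), compound 1 gives 1000 nM and stands level with compound 2 `O=C(N/N=C/c1ccc(Br)cc1)Nc1ccc(Oc2ccnc3[nH]ccc23)cc1`, which gives 1000 nM; together they are the lowest of the three numbers. Compound 3 `COc1ccc(/C=N/NC(=O)Nc2ccc(Oc3ccnc4[nH]ccc34)cc2)c(OC)c1OC` gives 2960 nM, the highest of the three. Among the measured compounds shown here, the one measured step, no change at the digits printed from compound 1 to compound 2 (within the scatter), concerns a different place in the molecule and so says little about the change at hand.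

Compound 4 `CN(C)CCn1cccc1/C=N/NC(=O)Nc1ccc(Oc2ccnc3[nH]ccc23)c(F)c1` differs from compound 1 in this way: 1-(2-(dimethylamino)ethyl)-1H-pyrrol-2-yl in place of 4-bromophenyl on a carbon with a double bond to nitrogen. Compound 3 shows that replacing the group at this place can raise the number, so a modest rise is expected, within the step of a 2.0-fold higher number from compound 1 to compound 4 (0.30 log units; within the scatter). Compound 4 is therefore estimated at 2000 nM, between 600 nM and 7000 nM.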

Compound 4, half-maximal inhibitory concentration: 8980 nM
For compound 4 the middle estimate is 4.5-fold (0.65 log units) below the measured one; the whole stated range lies below it.
By their numbers in this assay, from the lowest: compounds 1 and 2 (each within the scatter of the next); then compound 3; then compound 4.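

Putting 1-(2-(dimethylamino)ethyl)-1H-pyrrol-2-yl in place of 4-bromophenyl gives a 9.0-fold higher number from compound 1 to compound 4 (0.95 log units; beyond the scatter) in this assay. Among the compounds shown here, this is the first measured step at this place, on a carbon with a double bond to nitrogen, and it shows that the group there can change the number beyond the scatter. No measurement shown gives a reason for the rise.

This step swaps the ring and the chain together, so which part accounts for the rise stays open. A plain 1-methyl-1H-pyrrol-2-yl group would help separate the two.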